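The compounds below may be only part of what the source reports. "The series", "measured", "known", "first", "only" and "open" are said of these compounds alone.

Measured compounds:
compound 1, `COc1ccc(/C=C2\C(=O)N(c3c(Cl)cccc3Cl)c3ccccc32)cc1OC`, > 100 ug/mL
compound 2, `O=C1/C(=C\c2ccc(F)cc2)c2ccccc2N1c1c(Cl)cccc1Cl`, 13 ug/mL
compound 3, `O=C1/C(=C\c2cccc(Oc3ccccc3)c2)c2ccccc2N1c1c(Cl)cccc1Cl`, 24 ug/mL

All three values come from a functional assay on L132 cells (Homo sapiens) for cytotoxicity, read by MTT assay, with a stated time of 72 h; a higher number here means that more compound is needed for the effect, a lower number that less compound is needed. Compound 2 gives 13 ug/mL and compound 3 gives 24 ug/mL; compound 2 stands at the lower of the two numbers, but its gap to compound 3 is within the scatter, so no order between the two is claimed. For compound 1 the entry > 100 ug/mL is a limit of this assay and not a number; it sits at the limit of > 100 ug/mL in this assay, at which 1 of the 3 values shown sits.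

Compound 4, `O=C1/C(=C\c2ccccc2[N+](=O)[O-])c2ccccc2N1c1c(Cl)cccc1Cl`, is not yet measured in this assay. It differs from compound 2 by 2-nitrophenyl in place of 4-fluorophenyl on a double-bonded chain carbon bound to a double-bonded ring carbon. For the measured compounds named here, no pair of measured compounds shares this change, so the size of the step from compound 2 to compound 4 can only be expected, not read off. Among the measured compounds, the numbers for compound 2 and compound 3 sit close together, whereas compound 1 reaches only its limit; which way the present ring exchange falls is open. The step of a 1.5-fold higher number from compound 2 to compound 4 (0.19 log units; within the scatter) is expected to be small, toward a somewhat higher number, or none beyond the scatter. For compound 4 the estimate is 20 ug/mL, with a range from 8 ug/mL to 60 ug/mL.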

Compound 4, concentration for half-maximal effect: 10 ug/mL
Beside the measured number, compound 4's estimate is 2.0-fold (0.30 log units) above it, and the stated range covers the measured number.
By their numbers in this assay, from the lowest: compounds 4, 2 and 3 (each within the scatter of the next, the first and the last beyond it). At a limit, above all of these: compound 1.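

In this assay, 2-nitrophenyl in place of 4-fluorophenyl on a double-bonded chain carbon bound to a double-bonded ring carbon gives a 1.3-fold lower number from compound 2 to compound 4 (0.11 log units; within the scatter), so the two compounds cannot be told apart here, although 2-nitrophenyl has more heavy atoms than 4-fluorophenyl and carries hydrogen-bond acceptors that 4-fluorophenyl lacks. For the compounds shown here, the earlier compounds gave no step between two measured compounds differing in one place, so this is the first direct reading at this position, and in this one pair the position accepts the exchange with no difference beyond the scatter. No measurement shown here speaks to why the step has this size.

The exchange alters both the group on the phenyl ring and its place on that ring, and only a 4-nitrophenyl or a 2-fluorophenyl group at the same position would separate the two. From the compounds shown here alone, whether a 2-aminophenyl or a 4-carboxyphenyl group there would also stay within the scatter of compound 2 remains open.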